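Swapping an Imidazole for a Thiazole on a Biaryl Ether

This account rests on a few compounds, and the source may have more. Where it says the series, first, only, none or still open, it means among the compounds named here.

Measured so far, in a functional assay with Alpha-1A adrenergic receptor (Homo sapiens) as the target, read by calcium flux; a lower number here means a smaller maximal response, a higher number a larger maximal response:
- compound 1, `c1ccc(-c2ccsc2)c(OCC2=NCCN2)c1`, gives 98%
- compound 2, `c1ccc(-c2ccns2)c(OCC2=NCCN2)c1`, gives 99%
- compound 3, `c1ccc(-c2ncc[nH]2)c(OCC2=NCCN2)c1`, gives 122%

Compound 3 gives the highest of the three numbers. Its nearest neighbour is compound 2, reached by the step of a number 23 percentage points higher from compound 2 to compound 3 (beyond the scatter), and the furthest is compound 1, reached by the step of a number 24 percentage points higher from compound 1 to compound 3 (beyond the scatter). The two rings that do not carry a hydrogen-bond donor sit close together, as a number 1 percentage points higher from compound 1 to compound 2 (within the scatter) shows.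

Compound 4, `c1ccc(-c2nccs2)c(OCC2=NCCN2)c1`, has not yet been measured. It differs from compound 3 in one place: 1,3-thiazol-2-yl in place of 1H-imidazol-2-yl on an aromatic carbon. The group that leaves is the one with 1 hydrogen-bond donor; the group that enters has 0 hydrogen-bond donors and contains one sulfur, like the rings of compound 1 and compound 2.

Among the measured compounds shown here, the steps that bear on this change are the two that led up to compound 3, both modest and beyond the scatter. Since compound 4 returns to a ring with no donor, a step of similar size in the opposite direction is expected in this assay. Compound 4 is therefore expected to give 103%, with a range from 88% to 120%. The expected step is a number 19 percentage points lower from compound 3 to compound 4 (beyond the scatter).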

Compound 4, largest response reached (reported as maximum), in percent of the reference or control that the assay uses: 102%
Compound 4: middle estimate off by 1 percentage points, on the high side; low and high end bracket the measured number.
By their numbers in this assay, from the lowest: compounds 1, 2 and 4 (each within the scatter of the next); then compound 3.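

Within this assay the swap of 1H-imidazol-2-yl for 1,3-thiazol-2-yl gives a number 20 percentage points lower from compound 3 to compound 4 (beyond the scatter), so the larger response of compound 3 does not survive a change to another five-membered aromatic ring with 2 hetero atoms. Among the compounds shown here, the new ring also joins the other two sulfur rings, with a number 3 percentage points higher from compound 2 to compound 4 (within the scatter) and a number 4 percentage points higher from compound 1 to compound 4 (within the scatter), which means that among thiophen-3-yl, 1,2-thiazol-5-yl and 1,3-thiazol-2-yl the arrangement of atoms in the ring leaves no readable difference, and only compound 3, the one compound here whose ring has a hydrogen-bond donor, stands apart. No separate measurement is available to explain this gap.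

As far as these compounds go, all the rings without a donor here contain sulfur, so it stays open whether the step goes with losing the donor or with gaining sulfur: an oxazol-2-yl ring, with oxygen in place of sulfur, or a 1-methylimidazol-2-yl ring, with a methyl group on the ring nitrogen, would separate the two. Also open, from the compounds shown here alone, is how this assay would respond to a group outside this family of rings, such as an amine or a carboxylic acid, at this position.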